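Swapping Cyclohexyl for Methylthiazolyl on the Amide Carbonyl

A few compounds are considered here, and "the series" means these few. Any claim that something is new, unique, unknown or untested is made for them only; others in the source may bear on it.

In an assay on HEK293 cells for positive allosteric modulation of metabotropic glutamate receptor 5 (Homo sapiens), read by FLIPR, with a stated time of 1 h (on this read-out higher numbers stand for an effect only at larger amounts of compound and lower numbers for an effect already at smaller amounts), compound 1 `CN1CCc2nc(C#Cc3ccccc3)sc2C1` gives 34 nM. Compound 2 `CC(C)CN1CCc2nc(C#Cc3ccccc3)sc2C1` reaches only the limit of > 10000 nM in this assay. Compound 3 `O=C(C1CCCCC1)N1CCc2nc(C#Cc3ccccc3)sc2C1` gives 167 nM in this assay, the highest of the two real numbers shown, the other number being lower as a 4.9-fold higher number from compound 1 to compound 3 (0.69 log units; beyond the scatter) shows. Both an at least 290-fold higher number from compound 1 to compound 2 (2.46 log units; beyond the scatter) and an at least 59-fold lower number from compound 2 to compound 3 (1.77 log units; beyond the scatter) concern what sits on the ring amine nitrogen, not the group attached to the carbonyl. Compound 4 `Cc1nc(C(=O)N2CCc3nc(C#Cc4ccccc4)sc3C2)cs1` differs from compound 3 by 2-methyl-1,3-thiazol-4-yl in place of cyclohexyl on a carbonyl carbon. Among the compounds with values here, no measured step alters the group on the carbonyl carbon, so no shift beyond the usual scatter is expected. For compound 4 the expected step is a 1.1-fold lower number from compound 3 to compound 4 (0.05 log units; within the scatter). Compound 4 is therefore estimated at 150 nM, between 50 nM and 500 nM.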

Compound 4, half-maximal effective concentration: 220 nM
Estimate against measurement, compound 4: 1.5-fold (0.17 log units) below; low and high end bracket the measured number.
By their numbers in this assay, from the lowest: compound 1; then compounds 3 and 4 (each within the scatter of the next). At a limit, above all of these: compound 2.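

In this assay, the aromatic 2-methyl-1,3-thiazol-4-yl ring, with its 2 hydrogen-bond acceptors, can replace the non-aromatic cyclohexyl ring on this carbonyl carbon with no shift beyond the scatter: a 1.3-fold higher number from compound 3 to compound 4 (0.12 log units; within the scatter). The new group on the ring amine nitrogen still stands apart from both methyl and isobutyl, with a 6.5-fold higher number from compound 1 to compound 4 (0.81 log units; beyond the scatter) and an at least 45-fold lower number from compound 2 to compound 4 (1.65 log units; beyond the scatter). Compound 2 is held at a limit: the limit of > 10000 nM in this assay, at which 1 of the 4 values shown sits.

Still open, as far as these compounds go, is whether a phenyl ring, a pyridine ring or a longer chain on this carbonyl carbon would give a similar number. From the compounds shown here alone, the part played by the methyl of 2-methyl-1,3-thiazol-4-yl also remains open.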